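Furan to Thiophene: What to Expect for Compound 4

The source may report more compounds than this note shows. Statements on the series, on what has been measured and on what is new or still open speak of the compounds shown alone.

Three measured compounds share one core and differ only in the ester group or in the aromatic ring attached to a saturated ring carbon. In an assay on membranes from CHO cells for displacement of a labelled ligand from adenosine receptor A1 (Homo sapiens), read by scintillation counting, with a stated time of 60 min, tested at 1 uM (on this read-out lower numbers stand for less inhibition and higher numbers for more inhibition at the one concentration tested (going by the name of the read-out)), compound 1 `CCCOC(=O)C1=C(C)N(C)C(=O)NC1c1ccco1` gives 3%, compound 2 `CC1=C(C(=O)OCC(C)C)C(c2ccco2)NC(=O)N1C` gives 13%, and compound 3 `CC1=C(C(=O)OC(C)(C)C)C(c2ccco2)NC(=O)N1C` gives 44%. Compound 3 stands highest of the three: the step of a number 31 percentage points higher from compound 2 to compound 3 (beyond the scatter) and the step of a number 41 percentage points higher from compound 1 to compound 3 (beyond the scatter) both lie beyond the scatter, whereas the step of a number 10 percentage points higher from compound 1 to compound 2 (within the scatter) lies within it. Every measured step changes the ester alone.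

Compound 4 `CC1=C(C(=O)OC(C)(C)C)C(c2cccs2)NC(=O)N1C` keeps the tert-butyl ester of compound 3 and changes a different part: thiophen-2-yl in place of furan-2-yl on a saturated ring carbon. Within the data shown here, no measured pair shows a furan-to-thiophene swap, so the three ester steps do not bear on this change, and the only guide is that compound 3 starts at the top of the small set. The two rings counted here match in size, in hetero atom count and in hydrogen-bond acceptor count, which gives no reason to expect movement beyond the scatter. The estimated step of a number 4 percentage points lower from compound 3 to compound 4 (within the scatter) is therefore expected to be small, in either direction. Compound 4 is expected to give about 40%, with a range from 15% to 65%.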

Compound 4, a percentage reported as inhibition, at one concentration (the size of the read-out at that concentration, not a potency): 18%
Compound 4: the middle estimate sits 22 percentage points above what was measured, within the range that was stated.
By their numbers in this assay, from the lowest: compounds 1, 2 and 4 (each within the scatter of the next, the first and the last beyond it); then compound 3.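

Among these compounds, this is the first step in the set that leaves the ester alone and changes the aromatic ring on the saturated ring carbon, and it shows that this position matters in this assay: with the tert-butyl ester held constant, thiophen-2-yl in place of furan-2-yl gives a number 26 percentage points lower from compound 3 to compound 4 (beyond the scatter). The size of this step also shows that the counts for the two rings are a poor guide here, as both have the same number of heavy atoms, hetero atoms and hydrogen-bond acceptors, and they differ only in having sulfur or oxygen in the ring. No measurement offered here accounts for the drop.

Thiophen-2-yl appears here only with the tert-butyl ester, so it remains open whether the same ring change would move the number in the same direction with the propyl or isobutyl ester. Also open, on these data alone, is how a phenyl ring, a thiophen-3-yl ring or a furan-2-yl ring carrying an amine would read on this saturated ring carbon.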